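Removing a methoxy group from a sulfonyl indole

This account rests on a few compounds, and the source may have more. Where it says the series, first, only, none or still open, it means among the compounds named here.

Three compounds share an indole core that carries a phenyl group and an unsaturated side chain bearing a nitrile. Compound 1 `COc1ccc2[nH]c(-c3ccccc3)c(C=C(C#N)C#N)c2c1` gives 5400 nM in a functional assay on PC-3 cells (Homo sapiens) for inhibition, read by sulforhodamine B assay, with a stated time of 48 h; on this read-out higher numbers stand for weaker inhibition of growth and lower numbers for stronger inhibition of growth. Compound 2 `COc1ccc(-c2[nH]c3ccc(OC)cc3c2C=C(C#N)C#N)cc1` gives 342 nM in this assay. Compound 3 `COc1ccc2[nH]c(-c3ccccc3)c(/C=C(\C#N)S(=O)(=O)c3ccccc3)c2c1` gives 8300 nM in this assay, the highest of the three numbers; the gap to compound 1 lies within the scatter, while the gap to compound 2 lies beyond it. How the core of compound 3 differs from that of compound 2 is not broken down here.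

The difference between compound 2 and compound 1 is hydrogen in place of methoxy on an aromatic carbon, sitting para to a large group, and the step it made was a 16-fold higher number from compound 2 to compound 1 (1.20 log units; beyond the scatter). Compound 4 `N#C/C(=C\c1c(-c2ccccc2)[nH]c2ccccc12)S(=O)(=O)c1ccccc1` is not yet measured. It differs from compound 3 by hydrogen in place of methoxy on an aromatic carbon, the same kind of change, but here on a six-membered aromatic ring that is part of a fused or bridged system of two rings, meta to a fused ring and para to a fused ring, so the surroundings of the place are not the same.

Within the data shown here, because the only measured example, a 16-fold higher number from compound 2 to compound 1 (1.20 log units; beyond the scatter), went toward a higher number, compound 4 is expected to show a weaker inhibition of growth than compound 3 as well, with an estimated step of a 1.9-fold higher number from compound 3 to compound 4 (0.29 log units; within the scatter), though a smaller one, since the place differs. Compound 4 is expected to give about 16000 nM in this assay, between 5500 nM and 50000 nM.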

Compound 4, concentration for 50% growth inhibition: 3400 nM
Compound 4: the middle estimate sits 4.7-fold (0.67 log units) above what was measured; measured number below the stated range.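

In this assay, replacing methoxy with hydrogen on the sulfonyl compound gave a 2.4-fold lower number from compound 3 to compound 4 (0.39 log units; beyond the scatter), a modest step toward stronger inhibition of growth rather than the weaker inhibition seen on the other core. Set side by side, the two steps show that this change did not carry over from one core to the other in either direction or size: the same change on two cores in this assay, a 16-fold higher number (1.20 log units; beyond the scatter) from compound 2 to compound 1 and a 2.4-fold lower number (0.39 log units; beyond the scatter) from compound 3 to compound 4, 39-fold (1.59 log units) apart, beyond the scatter of two such steps The two pairs differ both in the side chain and in the ring that carries the change, so they do not show which of these separates the two outcomes, and with only two pairs they give no rule for any further core in the series.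

The compounds shown leave open whether a methoxy group on the phenyl group of the sulfonyl compounds would lower the number as it does in compound 2, which would allow the change to be compared on the same ring in both side-chain types. They also leave open whether other groups in place of the methoxy on the fused ring, such as a hydroxyl, an amine, a carboxylic acid or a longer chain like ethoxy, would move the number further in the same direction.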